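From 3,4-dimethoxyphenyl to 4-bromophenyl on the amide-type nitrogen

The source may report more compounds than this note shows. Statements on the series, on what has been measured and on what is new or still open speak of the compounds shown alone.

Measured in a functional assay on MDA-MB-231 cells (Homo sapiens) for cytotoxicity, read by MTT assay, with a stated time of 72 h; a lower number here means a stronger inhibitor, a higher number a weaker inhibitor:
- compound 1 `O=C(CN1CCN(c2nnc(Cc3ccccc3)c3ccccc23)CC1)Nc1c(F)cccc1F` gives 5490 nM
- compound 2 `Cc1ccc(F)cc1NC(=O)CN1CCN(c2nnc(Cc3ccccc3)c3ccccc23)CC1` gives 19200 nM
- compound 3 `COc1ccc(NC(=O)CN2CCN(c3nnc(Cc4ccccc4)c4ccccc34)CC2)cc1OC` gives 32200 nM

Compound 3 stands at 32200 nM. Its nearest neighbour on the numbers shows a 1.7-fold higher number from compound 2 to compound 3 (0.22 log units; within the scatter), and its furthest shows a 5.9-fold higher number from compound 1 to compound 3 (0.77 log units; beyond the scatter).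

The next compound, compound 4 `O=C(CN1CCN(c2nnc(Cc3ccccc3)c3ccccc23)CC1)Nc1ccc(Br)cc1`, carries 4-bromophenyl in place of 3,4-dimethoxyphenyl on an amide-type nitrogen.

All three measured steps change the group at this same place, so all three bear on the new one. Besides the two above, there is a 3.5-fold higher number from compound 1 to compound 2 (0.54 log units; beyond the scatter). Among the compounds with values here, no measured compound carries bromine, so these steps give only a likely size for the change, not a direct precedent. Within the data shown here, both compounds with a fluorinated group sit at lower numbers than compound 3, though only the step from the 2,6-difluorophenyl compound lies beyond the scatter. A modest move to a lower number therefore seems more likely than a move to a higher one, with no change beyond the scatter still possible.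

In this assay the expected step is a 2.5-fold lower number from compound 3 to compound 4 (0.39 log units; beyond the scatter).

For compound 4 the estimated value is 13000 nM, with an expected range from 4500 nM to 32000 nM.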

Compound 4, half-maximal inhibitory concentration: 12400 nM
Beside the measured number, compound 4's estimate is 1.0-fold (0.02 log units) above it; the range from low to high includes it.
By their numbers in this assay, from the lowest: compound 1; then compounds 4, 2 and 3 (each within the scatter of the next, the first and the last beyond it).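

In this assay, a 2.6-fold lower number from compound 3 to compound 4 (0.41 log units; beyond the scatter) shows that a step beyond the scatter away from the 3,4-dimethoxyphenyl compound does not depend on fluorine, as the 4-bromophenyl group carries bromine and no fluorine. The 4-bromophenyl and 5-fluoro-2-methylphenyl groups cannot be separated here: a 1.5-fold lower number from compound 2 to compound 4 (0.19 log units; within the scatter) places them together in the middle of the set, with one substituent on the ring of compound 4 and two on the ring of compound 2. With a 2.3-fold higher number from compound 1 to compound 4 (0.35 log units; beyond the scatter) as the remaining step, the 2,6-difluorophenyl group stays ahead of all three other groups on the amide-type nitrogen, so compound 1 is the strongest of the four in this set.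

No measurement at hand explains any of these differences, so the steps stand as observations only. Still open, from the compounds shown here alone, is whether 2,6-dichlorophenyl would match the 2,6-difluorophenyl group, and whether a carboxylic acid or an amine in place of the bromine of compound 4 would be tolerated at this position.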